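Triazole-linked spirooxindole series: antiproliferative readings on L02 cells

The compounds below may be only part of what the source reports. "The series", "measured", "known", "first", "only" and "open" are said of these compounds alone.

Measured compounds:
compound 1 `CCOc1ccccc1-n1nncc1CN1C(=O)C2(C(C#N)=C(N)Oc3c2c2nc4ccccc4nc2c2ccccc32)c2ccccc21`: > 50000 nM
compound 2 `CCOc1ccc(-n2nncc2CN2C(=O)C3(C(C#N)=C(N)Oc4c3c3nc5ccccc5nc3c3ccccc43)c3ccccc32)cc1`: > 50000 nM
compound 3 `CCOc1ccc(-n2nncc2CN2C(=O)C3(C(C#N)=C(N)Oc4c(N)cc5nc6ccccc6nc5c43)c3ccccc32)cc1`: > 50000 nM

All three values in an ADME assay on L02 cells (Homo sapiens) for antiproliferative activity, read by MTT assay, with a stated time of 48 h (a lower number here means a stronger inhibitor, a higher number a weaker inhibitor), are limits of the assay rather than numbers. Compound 1 stands at a limit. Compound 2 also stands at a limit. Compound 3 stands at a limit as well, as the limit of > 50000 nM in this assay, at which 3 of the 3 values shown sit, records. From compound 2 to compound 1 the change is 2-ethoxyphenyl in place of 4-ethoxyphenyl on an aromatic nitrogen, and the step that the two limits leave unreadable from compound 2 to compound 1 cannot be read because both ends are limits. The cores of compound 2 and compound 3 differ, but that difference is not broken down here. Compound 4 `CCOc1ccccc1-n1nncc1CN1C(=O)C2(C(C#N)=C(N)Oc3c(N)cc4nc5ccccc5nc4c32)c2ccccc21` carries the same change relative to compound 3, namely (2-ethoxyphenyl in place of 4-ethoxyphenyl on an aromatic nitrogen), with the same surroundings at the place of change. Compound 4 is therefore expected to remain at the limit, a step that the limit leaves unreadable from compound 3 to compound 4, resting on the unreadable step of compound 2 to compound 1. The estimate for compound 4 is 70000 nM, between 30000 nM and 250000 nM.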

Compound 4, half-maximal inhibitory concentration: > 50000 nM
Compound 4 was reported as a limit; the forecaster's own chance of this, stated with the estimate: 85%; the middle value does not contradict the limit.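

No step can be read from compound 3 to compound 4, since both stand at a limit: the limit of > 50000 nM in this assay, at which 4 of the 4 values shown sit.

The compounds shown leave open whether 2-ethoxyphenyl in place of 4-ethoxyphenyl changes the reading at all in this assay.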